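A few compounds are considered here, and "the series" means these few. Any claim that something is new, unique, unknown or untested is made for them only; others in the source may bear on it.

Measured compounds:
Compound 1, `COc1ccc(CNc2cc(OC)c(OC)c(OC)c2)cc1Cl`: 46200 nM
Compound 2, `COc1ccc(CN(C(=O)C=C(C)C)c2cc(OC)c(OC)c(OC)c2)cc1O`: 320 nM
Compound 3, `COC(=O)c1cc(CNc2cc(OC)c(OC)c(OC)c2)ccc1OC`: 49600 nM

All three were tested in a functional assay on MGC-803 cells (Homo sapiens) for inhibition, read by MTT assay, with a stated time of 48 h; a higher number here means a weaker inhibitor, a lower number a stronger inhibitor. Among them compound 2 stands lowest; compound 1 gives a number that is higher by a wide margin, and compound 3 gives one higher still, both well beyond the usual scatter. Compound 1 and compound 3 themselves sit close together: the step of a 1.1-fold higher number from compound 1 to compound 3 (0.03 log units; within the scatter) is within the scatter.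

The new compound is compound 4, `C/C=C/C(=O)N(Cc1ccc(OC)c(O)c1)c1cc(OC)c(OC)c(OC)c1`. It differs from compound 2 in one place: prop-1-en-1-yl in place of 2-methylprop-1-en-1-yl on a carbonyl carbon. The group that leaves and the group that enters both carry one double bond outside aromatic rings, and neither brings or removes a hydrogen-bond donor or acceptor.

Within the data shown here, only one measured step exists, and it concerns a methoxycarbonyl in place of chloro on an aromatic carbon, not the carbonyl carbon touched here. Among the measured compounds shown here, no measured pair shows what trimming the chain on the carbonyl carbon does in this assay. With nothing to point either way, the expectation is a step of a 1.3-fold higher number from compound 2 to compound 4 (0.10 log units; within the scatter) of no clear direction and small enough to fall within the scatter. Compound 4 is therefore estimated at 400 nM, with a likely range from 150 nM to 1100 nM.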

Compound 4, half-maximal inhibitory concentration: 27 nM
The estimate for compound 4 lay 15-fold (1.17 log units) above the measured number, and the stated range ends above it.
By their numbers in this assay, from the lowest: compound 4; then compound 2; then compounds 1 and 3 (each within the scatter of the next).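

In this assay the chain on the carbonyl carbon proves to matter: the step of a 12-fold lower number from compound 2 to compound 4 (1.07 log units; beyond the scatter) is large and lies beyond the scatter. It comes from swapping 2-methylprop-1-en-1-yl for prop-1-en-1-yl, which takes the group from 4 heavy atoms to 3 while leaving its count of double bonds and of hydrogen-bond donors and acceptors unchanged, so those counts do not separate the two groups. No earlier pair touched this position, and this pair shows that a small trim of the chain there can move the number far, though nothing available here explains why.

The compounds shown leave open how the number responds to other groups on the same carbonyl carbon: a plain methyl would show whether trimming further continues the trend, a saturated propyl chain whether the double bond is needed, and a longer chain whether added length reverses the change. From the compounds shown here alone, this is also a single pair on one core, so whether the same swap gives a step of similar size on a core with other ring substituents remains unknown.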